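The source may hold more compounds than are shown below. What is called first, only, known or untested is meant among the compounds shown, and "the series" means these compounds.

Compound 1, `Cc1c(-c2ccccc2)c(N2CC[C@H](N(C)C)C2)n2nc(C(C)(C)C)cc2c1C#N`, gives in a physicochemical assay for solubility, at pH 6.8 (on this read-out higher numbers stand for higher solubility and lower numbers for lower solubility), only a limit, < 2 ug/mL. Compound 2, `CCN(CC)CCNc1c(-c2ccccc2)c(C)c(C#N)c2nc(C(C)(C)C)nn12`, gives in this assay a value of 2 ug/mL. Compound 3, `Cc1c(-c2ccccc2)c(N2CC[C@H](N(C)C)C2)n2nc(C(C)(C)COCc3ccccc3)nc2c1C#N`, gives in this assay only a limit, < 3 ug/mL.

Compound 3 thus stands at the lower end of what this assay reports, with no number of its own. Two of the three values shown are limits: the limit of < 2 ug/mL in this assay, at which 1 of the 3 values shown sits, and (the limit of < 3 ug/mL in this assay, at which 1 of the 3 values shown sits). For the measured compounds named here, no step between measured compounds is available to read a direction from.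

Compound 4, `Cc1c(-c2ccccc2)c(N2CC[C@H](N(C)C)C2)n2nc(C(C)(C)CO)nc2c1C#N`, differs from compound 3 by hydrogen in place of benzyl on an oxygen on a saturated carbon. For compound 4 an increase beyond the scatter is expected, an at least 4.0-fold higher number from compound 3 to compound 4 (0.60 log units; beyond the scatter). The estimate for compound 4 is 12 ug/mL, within 3 ug/mL to 60 ug/mL.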

Compound 4, solubility: 140 ug/mL
For compound 4 the middle estimate is 12-fold (1.07 log units) below the measured one, and the stated range ends below it.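

In this assay, for the compounds shown here, hydrogen in place of benzyl on an oxygen on a saturated carbon gives an at least 46-fold higher number from compound 3 to compound 4 (1.66 log units; beyond the scatter) and is the first step that can be read; it is large and lifts compound 4 clear of the low values of the earlier compounds. On these data alone, compound 3 gives only a limit, so the printed step is a minimum and its true size stays unknown: the limit of < 3 ug/mL in this assay, at which 1 of the 4 values shown sits.

As far as these compounds go, whether a methyl ether, an amine or a carboxylic acid at this place would give a similar number remains open. So does whether the same change would act alike on the core of compound 2.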